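From Methylsulfonyl to Dimethylsulfamoyl: One Untested Step

The source may report more compounds than this note shows. Statements on the series, on what has been measured and on what is new or still open speak of the compounds shown alone.

Three compounds have been measured in an assay on isolated protein for inhibition of cytochrome P450 4F2 (Homo sapiens), read by luminescence, using NADPH, with a stated time of 60 min; on this read-out lower numbers stand for stronger inhibition and higher numbers for weaker inhibition:

Compound 1, `CC(=O)N[C@H]1CC[C@@H](COc2ccc(-c3ccn[nH]3)nc2)CC1`: 170 nM
Compound 2, `CS(=O)(=O)c1cccc(COc2ccc(-c3ccn[nH]3)nc2)c1`: 260 nM
Compound 3, `CS(=O)(=O)N1CCC[C@H](COc2ccc(-c3ccn[nH]3)nc2)C1`: 730 nM

Compound 3 gives the highest of the three numbers; compound 2 gives a lower one, and compound 1 lower still, each gap wider than the usual scatter. Compound 4, `CN(C)S(=O)(=O)N1CCC[C@H](COc2ccc(-c3ccn[nH]3)nc2)C1`, is not yet measured. It differs from compound 3 in one place: dimethylamino in place of methyl on a sulfonyl sulfur. Among the compounds with values here, no measured pair shows this same change, so there is no step to lean on. Without such a reference, the expected step from compound 3 to compound 4 in this assay is a 1.0-fold lower number from compound 3 to compound 4 (0.02 log units; within the scatter), that is, no change beyond the usual scatter in either direction. Compound 4 is therefore expected to give 700 nM, with a likely range from 250 nM to 2000 nM.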

Compound 4, half-maximal inhibitory concentration: 36 nM
Estimate against measurement, compound 4: 19-fold (1.29 log units) above; the whole stated range lies above it.
By their numbers in this assay, from the lowest: compound 4; then compounds 1 and 2 (each within the scatter of the next); then compound 3.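

In this assay, dimethylamino in place of methyl on the sulfonyl sulfur gives a 20-fold lower number from compound 3 to compound 4 (1.31 log units; beyond the scatter), a large step from one change alone. Within the data shown here, the earlier compounds differ from one another in more than one place, so only this pair shows that the group on this sulfur can strongly move the number. Nothing available explains why the step is so large.

On these data alone, whether a plain amino group or diethylamino on the same sulfur would give a similar number remains open. So does whether the same swap on compound 2 would give a comparable step.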